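The source may hold more compounds than are shown below. What is called first, only, known or untested is meant among the compounds shown, and "the series" means these compounds.

Going by the values given here, in a functional assay on the whole organism for antagonist activity, with Rattus norvegicus as the target (on this read-out higher numbers stand for an effect only at larger amounts of compound and lower numbers for an effect already at smaller amounts), compound 2 `CN1CCN(C(=O)CCCOc2cc(C(=O)N3CCCCc4sccc43)ccc2NC(=O)c2ccccc2-c2ccccc2)CC1` gives 0.03 mg/kg, the lowest number among the compounds measured so far. Compound 3 `CN(C)CCN1CCCN(C(=O)c2ccc(NC(=O)c3ccccc3-c3ccccc3)cc2)c2ccsc21` gives 0.31 mg/kg, a higher number, and the gap lies beyond the scatter. Compound 1 `O=C(Nc1ccc(C(=O)N2CCCN(CCN3CCCC3)c3sccc32)cc1)c1ccccc1-c1ccccc1` gives > 0.3 mg/kg, which is a limit and not a number. Compound 4 `CN1CCCN(C(=O)CCCOc2cc(C(=O)N3CCCCc4sccc43)ccc2NC(=O)c2ccccc2-c2ccccc2)CC1` differs from compound 2 in one place: 4-methyl-1,4-diazepan-1-yl in place of 4-methylpiperazin-1-yl on a carbonyl carbon. Among the compounds with values here, the only measured single change, a step that the limit leaves unreadable from compound 1 to compound 3, cannot be sized and involves a different group at a different place. Within the data shown here, with no measured step on this ring change, the expectation stays close to compound 2 at 0.03 mg/kg, with no step beyond the scatter in this assay. The expected step is a 1.3-fold higher number from compound 2 to compound 4 (0.12 log units; within the scatter). Compound 4 is estimated at 0.04 mg/kg, with an expected range from 0.01 mg/kg to 0.15 mg/kg.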

Compound 4, dose for 50% inhibition: 0.008 mg/kg
The estimate for compound 4 lay 5.0-fold (0.70 log units) above the measured number, and the stated range ends above it.
By their numbers in this assay, from the lowest: compound 4; then compound 2; then compound 3.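

In this assay, going by these compounds alone, 4-methyl-1,4-diazepan-1-yl in place of 4-methylpiperazin-1-yl on the carbonyl carbon gives a 3.8-fold lower number from compound 2 to compound 4 (0.57 log units; beyond the scatter), so the size of this ring matters even though the earlier compounds gave no measured step at this position. This single pair shows that the seven-membered ring can do better here than the six-membered one. Nothing measured here bears on the reason for this step. Still open, from the compounds shown here alone, is how a morpholine ring or an open-chain diethylamino group would behave on the same carbonyl carbon. Going by these compounds, whether the step carries over to other cores is also open.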